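The source may report more compounds than this note shows. Statements on the series, on what has been measured and on what is new or still open speak of the compounds shown alone.

In a functional assay on HL-60 cells (Homo sapiens) for antiproliferative activity, read by MTT assay, with a stated time of 72 h (a lower number here means a stronger inhibitor, a higher number a weaker inhibitor), two compounds with a shared core have been measured. Compound 1 `NC1=NC2(CCOCC2)N(OCCCOc2ccccc2)C(N)=N1` gives 2460 nM, and compound 2 `NC1=NC2(CCOCC2)N(OCCCOc2ccc(Br)cc2)C(N)=N1` gives 310 nM, the lower of the two numbers. Compound 3 `CC(C)(C)c1ccc(OCCCON2C(N)=NC(N)=NC23CCOCC3)cc1` differs from compound 2 at a single place, with tert-butyl in place of bromo on an aromatic carbon, para to a large group (tert-butyl in place of bromo on an aromatic carbon). For the measured compounds named here, no measured step exchanges one such group for another at this carbon, so the evidence is indirect. Going by the values given here, the only step that bears on it is a 7.9-fold lower number from compound 1 to compound 2 (0.90 log units; beyond the scatter), which put bromo in place of hydrogen at that carbon and lies beyond the scatter. Compound 3 still carries a group there rather than hydrogen, so it is expected to remain closer to compound 2 than to compound 1. No step beyond the scatter is expected in this assay, although the data cannot exclude one in either direction. The expected step is a 1.1-fold lower number from compound 2 to compound 3 (0.04 log units; within the scatter). For compound 3 the estimate is 280 nM, with an expected range of 100 nM to 800 nM.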

Compound 3, half-maximal inhibitory concentration: 870 nM
Estimate against measurement, compound 3: 3.1-fold (0.49 log units) below; measured number above the stated range.
By their numbers in this assay, from the lowest: compound 2; then compound 3; then compound 1.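

In this assay, this aromatic carbon proves sensitive to which group it carries, not only to whether it carries one: the exchange of bromo for tert-butyl gives a step beyond the scatter (a 2.8-fold higher number from compound 2 to compound 3 (0.45 log units; beyond the scatter)). Tert-butyl still keeps part of the gain seen with bromo, since replacing hydrogen with it also lowers the number (a 2.8-fold lower number from compound 1 to compound 3 (0.45 log units; beyond the scatter)), so both groups at this carbon give lower numbers than hydrogen, while the one with more heavy atoms gives the smaller gain. Nothing at hand measures why bromo and tert-butyl differ here.

What the compounds shown leave open is how other groups on this same carbon would rank against bromo, tert-butyl and hydrogen, for example chloro, methoxy, an amine or a carboxylic acid. Going by these compounds, it also remains open whether the same order would hold with these groups on another carbon of the aromatic ring, or with a longer chain in place of the present one.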